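Isopropyl in Place of Ethyl: An Expected Inhibition Value

The compounds below may be only part of what the source reports. "The series", "measured", "known", "first", "only" and "open" are said of these compounds alone.

Measured so far:
Compound 1, `CCc1ccccc1-c1cc2nc(N)nc(N)c2cc1C`: 41.1 nM
Compound 2, `CC(=O)c1cccc(-c2ccc3c(N)nc(N)nc3c2)c1`: 323 nM

Both compounds were tested in an assay on isolated protein for inhibition of Dihydrofolate reductase (Homo sapiens), read by spectrophotometry, using NADPH, with a stated time of 10 min; on this read-out lower numbers stand for stronger inhibition and higher numbers for weaker inhibition. Compound 1 gives 41.1 nM and stands at the lowest of the two numbers; compound 2 gives 323 nM, a higher number that lies beyond the scatter of this assay.

Compound 3, `Cc1cc2c(N)nc(N)nc2cc1-c1ccccc1C(C)C`, differs from compound 1 in one place: methyl in place of hydrogen on a saturated chain carbon bound to an aromatic carbon and a saturated chain carbon. Going by the values given here, no measured pair shows this kind of change, so its size is not anchored by any step in the data. A small step is expected, in either direction, most likely none beyond the scatter. Compound 3 is therefore expected to give 35 nM, with a range from 12 nM to 110 nM. This estimate means a step of a 1.2-fold lower number from compound 1 to compound 3 (0.07 log units; within the scatter), expected to remain within the usual scatter.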

Compound 3, inhibition constant: 20.9 nM
For compound 3 the middle estimate is 1.7-fold (0.22 log units) above the measured one; low and high end bracket the measured number.
By their numbers in this assay, from the lowest: compounds 3 and 1 (each within the scatter of the next); then compound 2.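

Going by these compounds alone, the change from ethyl to isopropyl gives a 2.0-fold lower number from compound 1 to compound 3 (0.29 log units; within the scatter) in this assay and is the first step here that can be read at all, as the earlier compounds formed no pair differing in one place. At this saturated chain carbon bound to an aromatic carbon and a saturated chain carbon, one further methyl therefore leaves the number within the scatter of the ethyl compound, so on this read-out the position accepts this added carbon without a measurable difference. No measurement shown here bears on why this is so.

As far as these compounds go, whether a longer chain, a tert-butyl group or a cyclopropyl ring at this carbon would also stay within the scatter remains open. From the compounds shown here alone, it is equally open how a hydroxyl group or an amine on this chain would read in this assay.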